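Phenyl on the Ring Nitrogen: What Three Limits Allow

The source may report more compounds than this note shows. Statements on the series, on what has been measured and on what is new or still open speak of the compounds shown alone.

Measured compounds in an assay on CHO cells for displacement of a labelled ligand from adenosine receptor A1 (Homo sapiens), read by scintillation counting, with a stated time of 90 min, in the presence of a further agent that is not named here; on this read-out higher numbers stand for weaker inhibition and lower numbers for stronger inhibition:
Compound 1 `CCCn1c(=O)[nH]c2nc(-c3ccc(S(=O)(=O)N4CCN(c5ccc(F)cc5)CC4)cc3)[nH]c2c1=O` gives > 1000 nM, which is a limit of the assay.
Compound 2 `CCCn1c(=O)[nH]c2nc(-c3ccc(S(=O)(=O)N4CCN(c5ccc(Br)cc5)CC4)cc3)[nH]c2c1=O` gives > 1000 nM, also a limit of the assay.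
Compound 3 `CCCn1c(=O)[nH]c2nc(-c3ccc(S(=O)(=O)N4CCN(C(C)c5ccccc5)CC4)cc3)[nH]c2c1=O` gives >= 1000 nM, again a limit of the assay.

Among the measured compounds shown here, compound 3 therefore stands at a limit, not at a number, and the two other values shown are limits as well, so no compound can be ranked against another. The steps a step that the two limits leave unreadable from compound 1 to compound 2, a step that the two limits leave unreadable from compound 1 to compound 3 and a step that the two limits leave unreadable from compound 2 to compound 3 are all unreadable for the same reason; the evidence consists only of the limit of > 1000 nM in this assay, at which 2 of the 3 values shown sit, and (the limit of >= 1000 nM in this assay, at which 1 of the 3 values shown sits).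

Compound 4 `CCCn1c(=O)[nH]c2nc(-c3ccc(S(=O)(=O)N4CCN(c5ccccc5)CC4)cc3)[nH]c2c1=O` differs from compound 3 by phenyl in place of 1-phenylethyl on an amine nitrogen in a ring. Compounds 1 and 2, which also carry an aromatic ring directly on that ring nitrogen, sit at the limit, so the change is expected to give no readable step: a step that the limit leaves unreadable from compound 3 to compound 4 is the step the estimate implies. Compound 4 is therefore expected to give 3000 nM in this assay, within a range of 1000 nM to 20000 nM, most likely reported as a limit again.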

Compound 4, inhibition constant: 364 nM
For compound 4 the middle estimate is 8.2-fold (0.92 log units) above the measured one; the whole stated range lies above it.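

In this assay, among the compounds shown here, compound 4 is the only compound here with a measured number rather than a limit, which shows that the group on this ring nitrogen can shift the read-out into a measurable range. Hydrogen in place of fluoro on the aromatic carbon gives an at least 2.7-fold lower number from compound 1 to compound 4 (0.43 log units; beyond the scatter), hydrogen in place of bromo gives an at least 2.7-fold lower number from compound 2 to compound 4 (0.43 log units; beyond the scatter), and phenyl in place of 1-phenylethyl gives an at least 2.7-fold lower number from compound 3 to compound 4 (0.43 log units; beyond the scatter). An aromatic ring directly on that nitrogen therefore does not by itself hold the value at the limit, since compound 4 carries one too, as do compounds 1 and 2, which stay at the limit.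

The steps among compounds 1, 2 and 3 cannot be read, and the three steps to compound 4 give only a minimum size. Going by these compounds, how a methoxy group or a methyl group on the phenyl ring would compare with the hydrogen of compound 4 stays open.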